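A few compounds are considered here, and "the series" means these few. Any claim that something is new, unique, unknown or untested is made for them only; others in the source may bear on it.

Compound 1 `O=C(/C(=C/c1ccccc1)CCl)c1ccccc1` carries a chloromethyl group on the chain, and in a functional assay on T47D cells (Homo sapiens) for inhibition, read by sulforhodamine B assay, with a stated time of 48 h (on this read-out lower numbers stand for stronger inhibition of growth and higher numbers for weaker inhibition of growth), compound 1 gives 18000 nM. Compound 2 `O=C(/C(=C/c1ccc(Cl)cc1)CCl)c1ccccc1` is the same core with chloro in place of hydrogen on an aromatic carbon, and in this assay compound 2 gives 17000 nM, so that a 1.1-fold lower number from compound 1 to compound 2 (0.02 log units; within the scatter). Compound 3 `CC(=O)OC/C(=C\c1ccc(Cl)cc1)C(=O)c1ccc(Cl)cc1` belongs to a second core, where an acetoxymethyl group replaces the chloromethyl group and a chloro group sits on the benzoyl ring; how this core differs from that of compound 1 is not broken down here. In this assay compound 3 gives 5400 nM, the lowest of the three numbers, beyond the scatter from compound 2 and from compound 1.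

Compound 4 `CC(=O)OC/C(=C\c1ccc(Cl)cc1Cl)C(=O)c1ccc(Cl)cc1` differs from compound 3 by chloro in place of hydrogen on an aromatic carbon. This is the same kind of change as that from compound 1 to compound 2, though the place differs: there the chloro entered para to a large group, here it enters ortho to a large group and meta to a chloro group. Because a 1.1-fold lower number from compound 1 to compound 2 (0.02 log units; within the scatter) lay within the scatter, the step from compound 3 to compound 4 is expected to be small as well, about a 1.2-fold lower number from compound 3 to compound 4 (0.08 log units; within the scatter). Compound 4 is therefore estimated at 4500 nM, most likely between 2000 nM and 10000 nM.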

Compound 4, concentration for 50% growth inhibition: 5200 nM
Compound 4: middle estimate off by 1.2-fold (0.06 log units), on the low side; the range from low to high includes it.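

In this assay the new step reads a 1.0-fold lower number from compound 3 to compound 4 (0.02 log units; within the scatter) and so, as on the core of compound 1, chloro in place of hydrogen on an aromatic carbon leaves the number within the scatter. Among the compounds shown here, this covers only two cores, with the chloro group entering at a different place on each, so it does not show that the same would hold at other places on the ring or on other cores. Within these two cores the change carries over without a visible difference: the same change on two cores in this assay, a 1.1-fold lower number (0.02 log units; within the scatter) from compound 1 to compound 2 and a 1.0-fold lower number (0.02 log units; within the scatter) from compound 3 to compound 4, 1.0-fold (0.01 log units) apart, within the scatter of two such steps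

The compounds shown leave open whether a methoxy group, a nitro group or an amine in place of the chloro group on this ring would shift the number beyond the scatter. They also leave open how a hydroxymethyl group or a longer ester chain in place of the acetoxymethyl group would read, and compound 1 and compound 3 differ in more than one place, so the share of each difference stays unresolved.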